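Swapping a Trifluoromethyl for a Methylsulfanyl Group

A few compounds are considered here, and "the series" means these few. Any claim that something is new, unique, unknown or untested is made for them only; others in the source may bear on it.

Of the compounds shown here, two have been tested so far, both sharing the same core and measured in a functional assay (aorta) with Rattus norvegicus as the target; a higher number here means a weaker inhibitor, a lower number a stronger inhibitor. Compound 1, `CC1(C)Oc2ccc(C#N)cc2[C@@H](NC(=O)c2ccccc2)[C@@H]1O`, gives 30 nM. Going by the values given here, compound 2, `CC1(C)Oc2ccc(C#N)cc2[C@@H](/N=C(\NC#N)Nc2cccc(C(F)(F)F)c2)[C@@H]1O`, gives 1600 nM, which is the higher of the two numbers; its only neighbour is compound 1, whose number is lower by a gap beyond the scatter.

The next compound, compound 3, `CSc1cccc(N/C(=N/[C@@H]2c3cc(C#N)ccc3OC(C)(C)[C@H]2O)NC#N)c1`, has not been measured. Compared with compound 2, the difference is methylsulfanyl in place of trifluoromethyl on an aromatic carbon. Among the compounds with values here, since no measured pair shows this exact change, the direction of the step is uncertain; a change from compound 2 to compound 3 of about a 1.3-fold higher number from compound 2 to compound 3 (0.10 log units; within the scatter) is expected, staying within the scatter. Compound 3 is therefore estimated at 2000 nM, with a plausible range from 600 nM to 7000 nM.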

Compound 3, half-maximal inhibitory concentration: 1400 nM
The estimate for compound 3 lay 1.4-fold (0.15 log units) above the measured number; the measured number falls inside the stated range.
By their numbers in this assay, from the lowest: compound 1; then compounds 3 and 2 (each within the scatter of the next).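

In this assay, putting methylsulfanyl in place of trifluoromethyl gives a 1.1-fold lower number from compound 2 to compound 3 (0.06 log units; within the scatter), a step within the scatter, so this assay does not separate the two groups at this position. Going by these compounds alone, this is the first measured change on this aromatic ring, and it shows that replacing the fluorine-bearing group with a smaller sulfur-bearing group that has a hydrogen-bond acceptor leaves the result within the scatter. The compounds carry no supporting measurement that could explain why the two groups read alike.

One matched pair cannot show whether this position tolerates other groups in general or whether these two simply happen to match. An amine, a carboxylic acid or a longer chain such as ethylsulfanyl at the same place would test how far that tolerance extends.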